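The source may hold more compounds than are shown below. What is called first, only, known or untested is meant among the compounds shown, and "the series" means these compounds.

Working notes on the series. Compound 1 (`Oc1cccc(CNc2ncnc3c2ncn3C2CCCCO2)c1`) gives > 100000 nM in an ADME assay on BJ cells (Homo sapiens) for cytotoxicity, read by MTT assay, with a stated time of 72 h (a lower number here means a stronger inhibitor, a higher number a weaker inhibitor), as a limit, not a number. Compound 2 (`COc1cccc(CNc2ncnc3c2ncn3C2CCCCO2)c1O`) gives > 100000 nM in this assay as a limit too. Compound 3 (`COc1cc(CNc2ncnc3c2ncn3C2CCCCO2)cc(OC)c1`) gives > 100000 nM in this assay as a limit as well. Among the compounds with values here, compound 1 thus stands with the others at the limit of > 100000 nM in this assay, at which 3 of the 3 values shown sit, and no measured step exists. Compound 4 (`Oc1cc(O)cc(CNc2ncnc3c2ncn3C2CCCCO2)c1`) has hydroxy in place of hydrogen on an aromatic carbon of compound 1, meta to a hydroxy group and meta to a large group (hydroxy in place of hydrogen on an aromatic carbon), so 3-hydroxyphenyl becomes 3,5-dihydroxyphenyl. The estimated a number no higher from compound 1 to compound 4 (the limit leaves the size open) is expected to stay within the scatter, in neither direction. This expectation rests only on compound 1, whose > 100000 nM is a limit. Compound 4 is expected near 100000 nM in a range of 50000 nM to 200000 nM by estimate.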

Compound 4, half-maximal inhibitory concentration: > 100000 nM
Compound 4 ended at the assay's limit (the forecaster's own chance of this, stated with the estimate: 85%); the middle value lies on the limit itself.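

No step can be read from compound 1 to compound 4, because both sit at the same limit: the limit of > 100000 nM in this assay, at which 4 of the 4 values shown sit. The compounds shown leave open what size of effect, if any, hydroxy in place of hydrogen has in this assay.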